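The source may report more compounds than this note shows. Statements on the series, on what has been measured and on what is new or still open speak of the compounds shown alone.

This account follows a set of amides sharing one core, tested in a functional assay on PC-3 cells (Homo sapiens) for cytotoxicity, read by XTT assay, with a stated time of 72 h; on this read-out lower numbers stand for stronger inhibition and higher numbers for weaker inhibition. Compound 1 `COc1ccc(CN(C)C(=O)c2ccc(-c3cc(-c4cc(OC)ccc4OC)no3)s2)cc1` carries a (4-methoxybenzyl)(methyl)amino group on the carbonyl carbon. In this assay compound 1 gives only a limit, > 30000 nM. Compound 2 `COc1ccc(OC)c(-c2cc(-c3ccc(C(=O)NC4CC4)s3)on2)c1` has a cyclopropylamino group in that place, and in this assay compound 2 gives 7800 nM, so the change brings an at least 3.8-fold lower number from compound 1 to compound 2 (0.58 log units; beyond the scatter). Compound 3 `COc1ccc(OC)c(-c2cc(-c3ccc(C(=O)NCC4CC4)s3)on2)c1` bears a (cyclopropylmethyl)amino group on the carbonyl carbon. In this assay compound 3 gives only a limit, > 30000 nM. Compound 3 therefore stands at the limit of > 30000 nM in this assay, at which 2 of the 3 values shown sit. The step of an at least 3.8-fold higher number from compound 2 to compound 3 (0.58 log units; beyond the scatter) leads to that limit, while the step that the two limits leave unreadable from compound 1 to compound 3.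

Compound 4 `COc1ccc(OC)c(-c2cc(-c3ccc(C(=O)N4CCCC4)s3)on2)c1` is not yet measured. It differs from compound 3 as follows: pyrrolidin-1-yl in place of (cyclopropylmethyl)amino on a carbonyl carbon. Compound 4, like compound 1, lacks the amide hydrogen. Within the data shown here, the steps bearing on it are the one from compound 2 to compound 3, which already reached the limit, and the unreadable one between compound 1 and compound 3, both amides without a readable number. Among the measured compounds shown here, no measured step suggests a return into the readable range. For compound 4 the expected step is a number no higher from compound 3 to compound 4 (the limit leaves the size open), nothing beyond the scatter. Compound 4 is estimated at 30000 nM, within a range from 10000 nM to 90000 nM.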

Compound 4, half-maximal inhibitory concentration: > 30000 nM
Compound 4 was reported as a limit; the forecaster's own chance of this, stated with the estimate: 70%; the middle value lies on the limit itself.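

Compound 4 stands with compound 1 and compound 3 in this assay, and its value is only a limit: the limit of > 30000 nM in this assay, at which 3 of the 4 values shown sit. Replacing the cyclopropylamino group with pyrrolidin-1-yl on the carbonyl carbon gives an at least 3.8-fold higher number from compound 2 to compound 4 (0.58 log units; beyond the scatter), so this five-membered ring does not keep the readable activity seen with the cyclopropylamino group. The steps that join compound 4 to compound 3 and to compound 1 run from limit to limit and cannot be read, but the four compounds do show that the amide hydrogen does not by itself separate readable from unreadable results: compound 2 has it and gives a number, compound 3 has it and sits at the limit, while compound 1 and compound 4 lack it and also sit at the limit.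

On these data alone, it stays open whether a smaller group on the amide nitrogen, such as methylamino or the plain primary amide, or a chain ending in an amine, such as 2-(dimethylamino)ethylamino, would give a readable number. The limits also leave open how far compound 1, compound 3 and compound 4 lie from one another.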